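The compounds below may be only part of what the source reports. "The series", "measured", "known", "first", "only" and "open" are said of these compounds alone.

Measured so far:
- compound 1 `CC[C@@H]1C(=O)N(C)c2cnc(-n3ccc4cc(F)ccc43)nc2N1C1CCCC1`, a functional assay on HeLa cells (Homo sapiens) for antiproliferative activity, read by CCK-8 assay, with a stated time of 72 h; a higher number here means a weaker inhibitor of growth, a lower number a stronger inhibitor of growth: "not active" (no number reported)
- compound 2 `CC[C@@H]1C(=O)N(C)c2cnc(Nc3ccc(S(=O)(=O)NC4CCCC4)cc3)nc2N1C1CCCC1`, same assay: 609 nM

Among the measured compounds shown here, compound 1 stands without any number in this assay: it is reported only as "not active" (no number reported), so no step can be drawn from it to anything else. Compound 2, a differently built analogue of the shared core, gives 609 nM, which shows that the core itself can reach measurable growth inhibition.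

Compound 3 `CC[C@@H]1C(=O)N(C)c2cnc(-n3ccc4cc(C(=O)NCC(C)C)ccc43)nc2N1C1CCCC1` differs from compound 1 in one place: isobutylcarbamoyl in place of fluoro on an aromatic carbon. For the measured compounds named here, no step between measured compounds resembles this change, so its size and direction cannot be read from the data. Given that compound 1 showed no activity, compound 3 is expected at best to move into the weakly measurable range, and the chance that the assay again reports only a limit stays substantial. Compound 3 is estimated at 3000 nM, within the range 500 nM to 20000 nM.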

Compound 3, concentration for 50% growth inhibition: 3280 nM
Estimate against measurement, compound 3: 1.1-fold (0.04 log units) below; measured number inside the range.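

No step can be read from compound 1 to compound 3: in this assay compound 1 stands as "not active" (no number reported), while compound 3 gives 3280 nM. The compounds shown leave open how large a change isobutylcarbamoyl in place of fluoro brings. No other evidence bears on this result.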